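The compounds below may be only part of what the source reports. "The series", "measured", "known", "first", "only" and "open" are said of these compounds alone.

Working notes on the series.

Compound 3 `O=c1nc2ccccn2cc1Cc1ccc(F)cc1` and compound 2 `O=c1nc2ccc(Br)cn2cc1Cc1ccccc1` are the two measured parents; the difference between the two cores is not broken down here. In a functional assay on HeLa cells (Homo sapiens) for cytotoxicity, read by MTT assay, with a stated time of 24 h (on this read-out lower numbers stand for stronger inhibition and higher numbers for weaker inhibition), compound 3 gives 139000 nM. In this assay compound 2 gives 152000 nM, which lies within the scatter of the value of compound 3, so no order between the two is drawn.

Compound 1 `Nc1cccn2cc(Cc3ccc(F)cc3)c(=O)nc12` is derived from compound 3 by amino in place of hydrogen on an aromatic carbon. In this assay compound 1 is recorded only as a limit, > 1000000 nM. Across this change the read-out moves by an at least 7.1-fold higher number from compound 3 to compound 1 (0.85 log units; beyond the scatter); the step can be given only as a lower bound because of the limit of > 1000000 nM in this assay, at which 1 of the 3 values shown sits.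

Compound 4 `Nc1cc(Br)cn2cc(Cc3ccccc3)c(=O)nc12` stands to compound 2 as compound 1 stands to compound 3, by amino in place of hydrogen on an aromatic carbon. The surroundings of the place are not identical: in compound 4 the entering amino is also meta to a bromo group (1 heavy atom), which compound 1 lacks, so this is the same kind of change, not the same change.

Within the data shown here, the expectation for compound 4 rests on the single measured precedent an at least 7.1-fold higher number from compound 3 to compound 1 (0.85 log units; beyond the scatter) from compound 3 to compound 1, and a step of comparable direction and size is expected, a 6.6-fold higher number from compound 2 to compound 4 (0.82 log units; beyond the scatter). For compound 4 the value in this assay is estimated at 1000000 nM, within 400000 nM to 3000000 nM, with a real chance that only a limit is returned.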

Compound 4, half-maximal inhibitory concentration: > 1000000 nM
Compound 4 ended at the assay's limit; the forecaster's own chance of this, stated with the estimate: 55%; the middle value lies on the limit itself.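

The second core repeats the first in direction: in this assay, amino in place of hydrogen on an aromatic carbon gives an at least 6.5-fold higher number from compound 2 to compound 4 (0.81 log units; beyond the scatter), so within these two pairs the change goes with weaker inhibition on both cores. Set beside the earlier step, this shows that the direction carries from the core of compound 3 to the core of compound 2, but it does not show that the size carries with it: the same change on two cores in this assay, an at least 7.1-fold higher number (0.85 log units; beyond the scatter) from compound 3 to compound 1 and an at least 6.5-fold higher number (0.81 log units; beyond the scatter) from compound 2 to compound 4; the limit leaves it open whether they differ. Neither step has a measured size, and each stands only as a lower bound, because the amino compounds reach the limit of the assay: the limit of > 1000000 nM in this assay, at which 2 of the 4 values shown sit.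

The compounds shown leave open how a methyl, hydroxyl, methoxy or dimethylamino group would read on the same aromatic carbon, and whether any such group would keep a value inside the measurable range of this assay. They also leave open how far the bromo group and the fluoro group each bear on the result, since the two cores differ in more than one place and no pair shown separates them.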